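The compounds below may be only part of what the source reports. "The series", "measured", "known", "first", "only" and "open" are said of these compounds alone.

Compound 1, `COc1ccc(-c2cc(-c3ccc4c(c3)CCCC4)nc(Cl)c2C#N)cc1OC`, gives in an ADME assay on RAW264.7 cells (Mus musculus) for cytotoxicity, with a stated time of 24 h (a higher number here means a weaker inhibitor, a lower number a stronger inhibitor), only a limit, > 50000 nM. Compound 2, `COc1ccc(-c2cc(-c3ccc4c(c3)CCCC4)nc(NCc3ccccc3)c2C#N)cc1OC`, gives 4900 nM in this assay, and this is the only plain number shown. Going by the values given here, the one measured step is an at least 10-fold lower number from compound 1 to compound 2 (1.00 log units; beyond the scatter). Compound 3, `CCOC(=O)COc1nc(-c2ccc3c(c2)CCCC3)cc(-c2ccc(OC)c(OC)c2)c1C#N`, differs from compound 2 by (ethoxycarbonyl)methoxy in place of benzylamino on an aromatic carbon. That measured step bears on this change only partly: it shows that bringing in the benzylamino lowered the number, so taking it out again may give part of that back. The expected step of a 4.1-fold higher number from compound 2 to compound 3 (0.61 log units; beyond the scatter) is toward a higher number. Compound 3 is estimated at 20000 nM, between 5000 nM and 60000 nM.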

Compound 3, half-maximal inhibitory concentration: 26200 nM
For compound 3 the middle estimate is 1.3-fold (0.12 log units) below the measured one; the range from low to high includes it.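

Replacing benzylamino with (ethoxycarbonyl)methoxy gives a 5.3-fold higher number from compound 2 to compound 3 (0.73 log units; beyond the scatter) in this assay, so the lower number of compound 2 does not carry over to every group at this position. The change from chloro gives an at least 1.9-fold lower number from compound 1 to compound 3 (0.28 log units; that floor lies within the scatter), and that floor lies within the scatter, so no order between these two compounds can be stated. Compound 1 gives only a limit, which leaves that step open: the limit of > 50000 nM in this assay, at which 1 of the 3 values shown sits.

The compounds shown leave open whether the lower number of compound 2 goes with the aromatic ring of benzylamino or with its nitrogen. A benzyloxy group and an ethylamino group at this position would separate the two.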